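The compounds below may be only part of what the source reports. "The series", "measured", "known", "first", "only" and "open" are said of these compounds alone.

Compound 1, `Cc1ccccc1S(=O)(=O)Nc1ccc2oc(-c3ccccc3)nc2c1`, in an assay on isolated protein for inhibition of malate dehydrogenase, mitochondrial (Sus scrofa), with stated times of 45 min and 30 min (a lower number here means a stronger inhibitor, a higher number a weaker inhibitor), reaches only the limit of the assay, > 63000 nM.
Compound 2, `O=S(=O)(Nc1ccc2oc(-c3ccccc3)nc2c1)c1ccccc1Cl`, in this assay likewise gives only the limit > 63000 nM.
Compound 3, `O=S(=O)(Nc1ccc2oc(-c3ccccc3)nc2c1)c1cccc(O)c1`, in this assay also gives only the limit > 63000 nM.

All three measured compounds share one core and differ only in the aryl group on the sulfonyl sulfur. Compound 3 therefore stands nowhere that can be ranked: its result is a limit, and the two other values are limits as well, so that the limit of > 63000 nM in this assay, at which 3 of the 3 values shown sit, describes every number seen. The steps a step that the two limits leave unreadable from compound 1 to compound 2, a step that the two limits leave unreadable from compound 1 to compound 3 and a step that the two limits leave unreadable from compound 2 to compound 3 cannot be read, since neither end of any of them is a real number.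

Compound 4, `COc1ccc(S(=O)(=O)Nc2ccc3oc(-c4ccccc4)nc3c2)cc1`, is not yet measured. It differs from compound 3 as follows: 4-methoxyphenyl in place of 3-hydroxyphenyl on a sulfonyl sulfur. None of the unreadable steps can say how large a change of this kind is, so no direction beyond the scatter can be drawn from them. The expected step is a step that the limit leaves unreadable from compound 3 to compound 4, which is to say no readable change. For compound 4 the estimate in this assay is 100000 nM, between 40000 nM and 400000 nM, most likely again only a limit.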

Compound 4, half-maximal inhibitory concentration: > 63000 nM
Compound 4: no number, only a limit; the forecaster's own chance of this, stated with the estimate: 85%; the middle value lies beyond the limit too.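

Compound 4, like compound 1, compound 2 and compound 3, gives only a limit and not a number, so no step among these compounds can be read: the limit of > 63000 nM in this assay, at which 4 of the 4 values shown sit.

The compounds shown leave open whether any aryl group on the sulfonyl sulfur of the shared core can give a real number in this assay at all.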